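A Dichlorophenyl Step Beyond Three Cytotoxicity Limits

The source may report more compounds than this note shows. Statements on the series, on what has been measured and on what is new or still open speak of the compounds shown alone.

Three compounds share one core and differ only in the aromatic group on a carbonyl carbon. Compound 1, `Cc1ccc2[nH]c(=O)c(CN(Cc3ccco3)C(=O)c3ccc(Cl)cc3)cc2c1`, carries chloro there. Compound 2, `Cc1ccc2[nH]c(=O)c(CN(Cc3ccco3)C(=O)c3ccc(Br)cc3)cc2c1`, carries bromo. Compound 3, `Cc1ccc2[nH]c(=O)c(CN(Cc3ccco3)C(=O)c3ccccc3)cc2c1`, carries hydrogen in that place. In an ADME assay on MT2 cells (Homo sapiens) for cytotoxicity, read by XTT assay, with a stated time of 4 days (on this read-out lower numbers stand for higher toxicity in this test and higher numbers for lower toxicity in this test), compound 1 gives > 61400 nM, which is a limit of the assay and not a number. In this assay compound 2 likewise gives only a limit, > 55400 nM. In this assay compound 3 also gives only a limit, > 67100 nM. Compound 3 therefore stands where the other two stand: all three values are limits, one each at the limit of > 55400 nM in this assay, at which 1 of the 3 values shown sits, at the limit of > 61400 nM in this assay, at which 1 of the 3 values shown sits, and at the limit of > 67100 nM in this assay, at which 1 of the 3 values shown sits. The steps between them cannot be read: a step that the two limits leave unreadable from compound 1 to compound 2, a step that the two limits leave unreadable from compound 1 to compound 3 and a step that the two limits leave unreadable from compound 2 to compound 3.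

Compound 4, `Cc1ccc2[nH]c(=O)c(CN(Cc3ccco3)C(=O)c3ccc(Cl)c(Cl)c3)cc2c1`, has not been measured. Its change from compound 3 is 3,4-dichlorophenyl in place of phenyl on a carbonyl carbon. The measured steps that bear on it are the chloro and bromo exchanges, and none of them has a readable size, so no step beyond the scatter in either direction can be expected in this assay. Compound 4 is expected to give 60000 nM, in a range from 30000 nM to 120000 nM. This expected step is an at least 1.1-fold lower number from compound 3 to compound 4 (0.04 log units; that floor lies within the scatter).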

Compound 4, half-maximal cytotoxic concentration: 70700 nM
Estimate against measurement, compound 4: 1.2-fold (0.07 log units) below; measured number inside the range.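

Going by these compounds alone, compound 4 gives a real number in this assay, but compound 1, compound 2 and compound 3 give only limits, so no step from any of them to compound 4 can be read. The compounds shown leave open where those three would reach their half-maximal cytotoxic concentration, and whether changing the aromatic group shifts that concentration at all.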